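The source may hold more compounds than are shown below. What is called first, only, known or untested is meant among the compounds shown, and "the series" means these compounds.

Measured in a functional assay on SK-MEL-28 cells (Homo sapiens) for inhibition; on this read-out higher numbers stand for weaker inhibition of growth and lower numbers for stronger inhibition of growth:
compound 1 `COc1cc(/C=C/C(=O)c2cccc(-n3cc(-c4ccc(Cl)cc4)[nH]c3=O)c2)cc(OC)c1OC` gives 10900 nM
compound 2 `COc1cc(/C=C/C(=O)c2cccc(-n3cc(-c4ccccc4)[nH]c3=O)c2)ccc1O` gives 1850 nM
compound 3 `COc1cc(/C=C/C(=O)c2cccc(-n3cc(-c4ccccc4)[nH]c3=O)c2)cc(OC)c1OC` gives 1740 nM

Compound 2 holds the second highest of the three numbers. Its nearest neighbour is compound 3, whose value lies within the scatter of that of compound 2, so no order between these two can be read. Compound 1 is furthest from compound 2, with a higher number that is beyond the scatter.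

Compound 4 `COc1cc(/C=C/C(=O)c2cccc(-n3cc(-c4ccc(Cl)cc4)[nH]c3=O)c2)ccc1O` has not yet been measured in this assay. It differs from compound 2 by chloro in place of hydrogen on an aromatic carbon; the same difference, cut one bond further out, reads phenyl to 4-chlorophenyl, the chloro standing para to a large group. Going by the values given here, one measured step bears directly on this change, run in the opposite direction: a 6.3-fold lower number from compound 1 to compound 3 (0.80 log units; beyond the scatter), with compound 1 and compound 3 differing from compound 2 and compound 4 elsewhere in the molecule. Reversing that step gives the expectation of a higher number, beyond the scatter, and hence weaker inhibition of growth. The expected step is a 5.9-fold higher number from compound 2 to compound 4 (0.77 log units; beyond the scatter). Compound 4 is therefore estimated at 11000 nM, with a range from 4000 nM to 30000 nM, resting on a single measured pair only.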

Compound 4, concentration for 50% growth inhibition: 2060 nM
Compound 4: middle estimate off by 5.3-fold (0.73 log units), on the high side; the measured number lies below the stated range.
By their numbers in this assay, from the lowest: compounds 3, 2 and 4 (each within the scatter of the next); then compound 1.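

In this assay, chloro in place of hydrogen on this aromatic carbon, para to a large group, now gives a 1.1-fold higher number from compound 2 to compound 4 (0.05 log units; within the scatter), so no loss of inhibition of growth can be read for this change on this core. The weakening seen earlier with phenyl to 4-chlorophenyl therefore does not hold as a general rule for this position, and compound 1 remains the only case of it among the compounds shown. The outcome of the change depends on the core that carries it: the same change on two cores in this assay, a 6.3-fold lower number (0.80 log units; beyond the scatter) from compound 1 to compound 3 and a 1.1-fold lower number (0.05 log units; within the scatter) from compound 4 to compound 2, 5.6-fold (0.75 log units) apart, beyond the scatter of two such steps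

Which feature of the two cores governs this dependence stays open, as only one pair per core is available and the cores differ in more than one place. Also open, from the compounds shown here alone, is whether a fluoro, a trifluoromethyl or an amine on the same aromatic carbon would follow the pattern of compound 1 or the pattern of compound 4 on either core.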